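Swapping chloro for nitro on a thiosemicarbazone ring

A few compounds are considered here, and "the series" means these few. Any claim that something is new, unique, unknown or untested is made for them only; others in the source may bear on it.

Compound 1 `Oc1ccc(/C=N/NC(=S)Nc2ccccc2)cc1`: 242000 nM
Compound 2 `Oc1ccc(/C=N/NC(=S)Nc2ccc(Cl)cc2)cc1`: 287000 nM
Compound 3 `Oc1ccc(/C=N/NC(=S)Nc2cccc(Cl)c2)cc1`: 29300 nM

These three compounds were tested in an assay for inhibition of ribonucleoside-diphosphate reductase RR1 (Homo sapiens), with a stated time of 30 min; a lower number here means a stronger inhibitor, a higher number a weaker inhibitor. Compound 2 and compound 1 give numbers within the scatter of each other, while compound 3 gives a clearly lower number. The step of a 1.2-fold higher number from compound 1 to compound 2 (0.07 log units; within the scatter) shows one chloro placement changing nothing; the step of an 8.3-fold lower number from compound 1 to compound 3 (0.92 log units; beyond the scatter) shows another placement helping modestly. Compound 4 `O=[N+]([O-])c1ccc(NC(=S)N/N=C/c2ccc(O)cc2)cc1` differs from compound 2 by nitro in place of chloro on an aromatic carbon. Going by the values given here, no measured pair swaps chloro for nitro; the only step bearing on this position is a 1.2-fold higher number from compound 1 to compound 2 (0.07 log units; within the scatter), which left the number unchanged. Compound 4 is therefore expected to change little: a 1.3-fold lower number from compound 2 to compound 4 (0.12 log units; within the scatter). Compound 4 is estimated at 220000 nM, from 50000 nM to 900000 nM.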

Compound 4, half-maximal inhibitory concentration: 45100 nM
Beside the measured number, compound 4's estimate is 4.9-fold (0.69 log units) above it; measured number outside the range, below it.
By their numbers in this assay, from the lowest: compounds 3 and 4 (each within the scatter of the next); then compounds 1 and 2 (each within the scatter of the next).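

In this assay, the position on an aromatic carbon para to a large group proves sensitive to which group sits there, which the chloro of compound 2 alone did not reveal. Nitro gives a 6.4-fold lower number from compound 2 to compound 4 (0.80 log units; beyond the scatter) and also a 5.4-fold lower number from compound 1 to compound 4 (0.73 log units; beyond the scatter) on the same shared core, so this position is not indifferent to substitution. Nothing given here explains why nitro and chloro part ways at this position. As far as these compounds go, whether an amine or a carboxylic acid at this position would also lower the number remains open, as does the effect of nitro at the chloro placement of compound 3.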